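Swapping a heptyl chain for cyclohexyl on the shared core

This account rests on a few compounds, and the source may have more. Where it says the series, first, only, none or still open, it means among the compounds named here.

Compound 3 `CCCCCCCC1C=C(Br)CCN1S(=O)(=O)c1ccc(C)cc1` gives the highest of the three numbers measured in a functional assay on WiDr cells (Homo sapiens) for antiproliferative activity, read by sulforhodamine B assay, with a stated time of 48 h (a higher number here means a weaker inhibitor of growth, a lower number a stronger inhibitor of growth), at 40000 nM. Its nearest neighbour is compound 1 `Cc1ccc(S(=O)(=O)N2CCC(Cl)=CC2C2CCCCC2)cc1`, which in this assay gives 24000 nM, a gap that stays within the scatter. Compound 2 `Cc1ccc(S(=O)(=O)N2CCC(Br)=CC2CC(C)C)cc1` gives 16000 nM in this assay. Going by the values given here, the one step that can be read across these compounds is the lengthening of the chain on a saturated chain carbon bound to a saturated ring carbon, which gave a 2.5-fold higher number from compound 2 to compound 3 (0.40 log units; beyond the scatter).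

Compound 4 `Cc1ccc(S(=O)(=O)N2CCC(Br)=CC2C2CCCCC2)cc1` differs from compound 3 by cyclohexyl in place of heptyl on a saturated ring carbon. Among the compounds with values here, no measured step joins a heptyl to a cyclohexyl on that carbon, so the expectation rests on two points: the chain step above changed the number only modestly, and compound 1, which carries the same cyclohexyl on this carbon but a chloro group in place of bromo, sits within the scatter of compound 3. Compound 4 is therefore expected to show a 1.8-fold lower number from compound 3 to compound 4 (0.26 log units; within the scatter), a change not beyond the scatter, with an estimated value of 22000 nM and a range from 9000 nM to 55000 nM.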

Compound 4, concentration for 50% growth inhibition: 18000 nM
Compound 4: middle estimate off by 1.2-fold (0.09 log units), on the high side; the measured number falls inside the stated range.
By their numbers in this assay, from the lowest: compounds 2, 4, 1 and 3 (each within the scatter of the next, the first and the last beyond it).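

In this assay, cyclohexyl in place of heptyl on the saturated ring carbon gave a 2.2-fold lower number from compound 3 to compound 4 (0.35 log units; beyond the scatter), which shows directly, with the bromo group held constant, that the group at this position can shift the number modestly. Cyclohexyl in place of isobutyl at the same carbon gave a 1.1-fold higher number from compound 2 to compound 4 (0.05 log units; within the scatter), and bromo in place of chloro on the double-bonded ring carbon gave a 1.3-fold lower number from compound 1 to compound 4 (0.12 log units; within the scatter), so neither of these two changes separates its pair of compounds. Nothing available here explains these differences.

The compounds shown leave open whether a phenyl ring or a chain ending in an amine on the saturated ring carbon would move the number beyond the scatter from compound 4. They also leave open how iodo or fluoro would compare with bromo on the double-bonded ring carbon.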